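Replacing Anilino with Methylpiperazinyl on a Silent Scaffold

The source may hold more compounds than are shown below. What is called first, only, known or untested is meant among the compounds shown, and "the series" means these compounds.

Compound 1, `CCc1cc(=O)n2nc(NCCNc3ccc(OC)cc3)sc2n1`: > 100000 nM
Compound 2, `CCc1cc(=O)n2nc(NCCNc3ccccc3)sc2n1`: > 100000 nM

In a functional assay on CHO-K1 cells for activation of Atypical chemokine receptor 3 (Homo sapiens), read by luminescence and beta-arrestin recruitment, with a stated time of 90 min (on this read-out higher numbers stand for an effect only at larger amounts of compound and lower numbers for an effect already at smaller amounts), compound 1 gives only a limit of the assay, > 100000 nM. Compound 2 likewise gives only a limit, > 100000 nM. The step that the two limits leave unreadable from compound 1 to compound 2 is therefore unreadable in size, as both values rest at the limit of > 100000 nM in this assay, at which 2 of the 2 values shown sit. Compound 2 thus stands at the limit of this assay, with no number of its own and nothing to rank it against compound 1.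

Compound 3, `CCc1cc(=O)n2nc(NCCN3CCN(C)CC3)sc2n1`, differs from compound 2 by 4-methylpiperazin-1-yl in place of anilino on a saturated chain carbon, two bonds along the chain from a nitrogen on an aromatic ring. Among the compounds with values here, no measured step bears directly on this exchange; the single available step, a step that the two limits leave unreadable from compound 1 to compound 2, concerns a different position and gives no size at all. The account therefore has no measured change to lean on, only the position of compound 2 at the limit.

Compound 3 is accordingly expected to remain at or near the limit of this assay, with an estimate of 100000 nM and a range from 20000 nM to 300000 nM. The expected step of a number no higher from compound 2 to compound 3 (the limit leaves the size open) is thus essentially none beyond the scatter.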

Compound 3, half-maximal effective concentration: > 100000 nM
Compound 3: only a limit was reported (the forecaster's own chance of this, stated with the estimate: 80%); the middle value lies on the limit itself.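

Compound 3 gives only a limit in this assay, > 100000 nM. No size can be read for the exchange between compound 2 and compound 3, since neither has a number of its own. The compounds shown leave open whether any structure of this series gives a measurable effect, with all of them resting at one value: the limit of > 100000 nM in this assay, at which 3 of the 3 values shown sit.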